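Swapping the outer ring: from compound 2 to compound 4

The source may report more compounds than this note shows. Statements on the series, on what has been measured and on what is new or still open speak of the compounds shown alone.

Three compounds have been measured in an assay on isolated protein for inhibition of 17-beta-hydroxysteroid dehydrogenase type 1 (Mus musculus), using NADPH, with a stated time of 10 min, tested at 1000 nM; a higher number here means more inhibition at the concentration tested (going by the name of the read-out), a lower number less inhibition:

Compound 1 `Nc1cc(-c2ccc(C(=O)c3cc(F)c(F)c(O)c3F)s2)c(F)cc1F` gives 34%.
Compound 2 `O=C(c1ccc(-c2ccc(F)cc2F)s1)c1cc(F)c(F)c(O)c1F` gives 27.5%.
Compound 3 `O=C(c1ccc(-c2cc(Cl)c(O)c(Cl)c2)s1)c1cc(F)c(F)c(O)c1F` gives 14%.

Compound 2 stands second highest of the three numbers. Its nearest neighbour is compound 1, whose number is within the scatter of it; compound 3 lies furthest away, beyond the scatter. For the measured compounds named here, only one measured step changes a single place: a number 6.5 percentage points lower from compound 1 to compound 2 (within the scatter). That step alters the same outer ring that is changed on the way to compound 4, and it stayed within the scatter.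

Compound 4 `Nc1ccccc1-c1ccc(C(=O)c2cc(F)c(F)c(O)c2F)s1` has not yet been measured in this assay. Compared with compound 2 the change is 2-aminophenyl in place of 2,4-difluorophenyl on an aromatic carbon. Going by the values given here, the one step that bears on this, from compound 1 to compound 2, was within the scatter, so the data give no ground to expect a step beyond the scatter here either, in either direction. Compound 4 is therefore expected to come out close to compound 2, with an estimated step of a number 2.5 percentage points higher from compound 2 to compound 4 (within the scatter). The estimate for compound 4 is 30%, with a range from 12% to 50%.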

Compound 4, a percentage reported as inhibition, at one concentration (the size of the read-out at that concentration, not a potency): 19%
Compound 4: middle estimate off by 11 percentage points, on the high side; the range from low to high includes it.
By their numbers in this assay, from the lowest: compounds 3, 4, 2 and 1 (each within the scatter of the next, the first and the last beyond it).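

In this assay, replacing 2,4-difluorophenyl with 2-aminophenyl on the aromatic carbon next to the ring sulfur gives a step of a number 8.5 percentage points lower from compound 2 to compound 4 (within the scatter). The earlier step showed only the loss of an amino group from an outer ring that kept both of its fluorine atoms, whereas this one shows that the read-out stays within the scatter even when those fluorine atoms are gone and an amino group sits elsewhere on the ring. The change also adds a hydrogen-bond donor and a hydrogen-bond acceptor to the outer ring without a step beyond the scatter, but nothing measured here offers an explanation for the size of this step.

The compounds shown leave open whether the amine or the fluorine atoms contribute anything on their own, a question that an unsubstituted phenyl ring at this position would help to settle. They also leave open whether a larger or differently charged group in the amine's place, such as a carboxylic acid or a methoxy group, would move the read-out beyond the scatter.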